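The compounds below may be only part of what the source reports. "The series", "measured", "known", "first", "only" and "open" are said of these compounds alone.

Compound 1 `Cc1ccc(OCC(=O)N(Cc2cccs2)c2cccnc2)cc1` — in an assay on HEK293 cells for agonist activity at transient receptor potential cation channel subfamily M member 8 (Homo sapiens), read by fluorescence and calcium flux, with a stated time of 15 min (on this read-out higher numbers stand for an effect only at larger amounts of compound and lower numbers for an effect already at smaller amounts), compound 1 gives 198 nM.
Compound 2 `Cc1ccc(OCC(=O)N(CCO)Cc2cccs2)cc1` — in this assay compound 2 gives 900 nM.

Compound 2 holds the higher of the two numbers, the step of a 4.5-fold higher number from compound 1 to compound 2 (0.66 log units; beyond the scatter) lying beyond the scatter. Compound 3 `Cc1ccc(OCC(=O)N(Cc2cccs2)c2ncccn2)cc1` differs from compound 2 by pyrimidin-2-yl in place of 2-hydroxyethyl on an amide-type nitrogen. For the measured compounds named here, the only step that bears on this change is a 4.5-fold higher number from compound 1 to compound 2 (0.66 log units; beyond the scatter), where a ring on this nitrogen gave way to 2-hydroxyethyl and the number rose. Restoring a six-membered aromatic ring is therefore expected to lower the number in this assay by a comparable amount. For compound 3 the expected value is 250 nM (range 100 nM to 700 nM), a step of a 3.6-fold lower number from compound 2 to compound 3 (0.56 log units; beyond the scatter).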

Compound 3, half-maximal effective concentration: 3700 nM
For compound 3 the middle estimate is 15-fold (1.17 log units) below the measured one; the measured number lies above the stated range.
By their numbers in this assay, from the lowest: compound 1; then compound 2; then compound 3.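

In this assay a six-membered aromatic ring on this amide-type nitrogen does not by itself give a low number: pyrimidin-2-yl in place of 2-hydroxyethyl gives a 4.1-fold higher number from compound 2 to compound 3 (0.61 log units; beyond the scatter) and not a drop. Pyrimidin-2-yl in place of pyridin-3-yl gives a 19-fold higher number from compound 1 to compound 3 (1.27 log units; beyond the scatter) here, so these two rings are not interchangeable at this place. Going by these compounds, whether phenyl would stand nearer to pyridin-3-yl or to pyrimidin-2-yl remains open, as does how a 2-aminoethyl chain would compare with 2-hydroxyethyl. Nothing given here accounts for the gap between the two rings.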